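Swapping one aromatic group at the amide end

The source may report more compounds than this note shows. Statements on the series, on what has been measured and on what is new or still open speak of the compounds shown alone.

Compound 3 `O=C(c1ccccc1)c1cccc(NC(=O)C2CCCN(C(=O)c3cc(C(F)(F)F)cc(C(F)(F)F)c3)C2)c1` gives 0% in an ADME assay on PC-3 cells (Homo sapiens) for cytotoxicity, read by WST assay, tested at 100 uM (a lower number here means less inhibition, a higher number more inhibition at the concentration tested (going by the name of the read-out)), which sets it level with compound 1 `O=C(Nc1cccc(-c2ccco2)c1)C1CCCN(C(=O)c2cc(C(F)(F)F)cc(C(F)(F)F)c2)C1` at 0% and makes the two together the lowest of three numbers; compound 2 `O=C(Nc1ccc(Cl)cc1)C1CCCN(C(=O)c2cccc(-c3nccs3)c2)C1`, which differs from both in more than one place, sits higher at 32%. Compound 4 `Cc1nc(-c2cccc(NC(=O)C3CCCN(C(=O)c4cc(C(F)(F)F)cc(C(F)(F)F)c4)C3)c2)cs1` is one step away from compound 3: 2-methyl-1,3-thiazol-4-yl in place of benzoyl on an aromatic carbon. Among the measured compounds shown here, the only measured step that bears on this, no change at the digits printed from compound 1 to compound 3 (within the scatter), shows that exchanging one aromatic group in that same spot left the inhibition read-out unchanged, so another such exchange is expected to do the same. Compound 4 is therefore expected at 5%, between 0% and 20%. That amounts to an expected step of a number 5 percentage points higher from compound 3 to compound 4 (within the scatter).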

Compound 4, a percentage reported as inhibition, at one concentration (the size of the read-out at that concentration, not a potency): 1%
Estimate against measurement, compound 4: 4 percentage points above; the measured number falls inside the stated range.
By their numbers in this assay, from the lowest: compounds 1, 3 and 4 (each within the scatter of the next); then compound 2.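

Putting 2-methyl-1,3-thiazol-4-yl in place of benzoyl gives a number 1 percentage points higher from compound 3 to compound 4 (within the scatter), and putting it in place of furan-2-yl gives a number 1 percentage points higher from compound 1 to compound 4 (within the scatter), both in this assay. This position has now carried a third aromatic group, one with two hetero atoms in a five-membered ring, and the read-out still does not separate the compounds. No supporting measurement is available to explain this. On these data alone, whether a non-aromatic group here, such as an amine or a carboxylic acid, would give a similar number remains open.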